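This account rests on a few compounds, and the source may have more. Where it says the series, first, only, none or still open, it means among the compounds named here.

Measured compounds, with their numbers in a functional assay on MGC-803 cells (Homo sapiens) for antiproliferative activity, read by MTT assay, with a stated time of 48 h; a lower number here means a stronger inhibitor, a higher number a weaker inhibitor:

Compound 1 `O=C(Nc1cccc(CNc2nccnc2Cl)c1)Nc1ccccc1Cl` gives 7130 nM.
Compound 2 `O=C(Nc1cccc(CNc2nccnc2Cl)c1)Nc1ccccc1F` gives 6440 nM.
Compound 3 `O=C(Nc1ccc(Cl)cc1)Nc1cccc(CNc2nccnc2Cl)c1` gives 4980 nM.

Compound 1 has the highest of the three numbers, but every gap is small: a 1.1-fold lower number from compound 1 to compound 2 (0.04 log units; within the scatter), and a 1.4-fold lower number from compound 1 to compound 3 (0.16 log units; within the scatter). Neither change separates the compounds beyond the usual scatter, so all three are best read as alike in this assay.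

Compound 4 `O=C(Nc1cccc(CNc2nccnc2Cl)c1)Nc1ccc(Cl)cc1Cl` is the untested one. Its difference from compound 1 is chloro in place of hydrogen on an aromatic carbon. The resulting 2,4-dichlorophenyl ring combines the features of compound 1, which carries the 2-chlorophenyl, and compound 3, which carries the 4-chlorophenyl. Within the data shown here, the steps that bear on it are the two already mentioned, both within the scatter, and the step from compound 2 to compound 3 was likewise within the scatter. Compound 4 is therefore expected to land close to compound 1, with perhaps a slight movement toward a lower number, as a 1.3-fold lower number from compound 1 to compound 4 (0.11 log units; within the scatter). The estimate for compound 4 is 5500 nM, in a range from 2500 nM to 12000 nM.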

Compound 4, half-maximal inhibitory concentration: 6430 nM
Beside the measured number, compound 4's estimate is 1.2-fold (0.07 log units) below it, and the stated range covers the measured number.
By their numbers in this assay, from the lowest: compounds 3, 4, 2 and 1 (each within the scatter of the next).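

In this assay, a second chloro on the ring of compound 1, para to a large group, leaves the number within the scatter (a 1.1-fold lower number from compound 1 to compound 4 (0.04 log units; within the scatter)). Among these compounds, the 2,4-dichlorophenyl ring reads the same way when set against the other two single-halogen rings, with a 1.3-fold higher number from compound 3 to compound 4 (0.11 log units; within the scatter) and a 1.0-fold lower number from compound 2 to compound 4 (0.00 log units; within the scatter), so this is the first sign that two halogens on this ring give a result alike to one. Nothing measured here explains this result.

All the compounds shown carry only halogens on this ring, so how a methoxy group, an amine or a carboxylic acid would read at this position remains open. Also open, on these data alone, is whether any change to the shared core, rather than to this ring, would move the number beyond the scatter.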